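Swapping a Thiophene for a Trifluoromethylphenyl Ring

The compounds below may be only part of what the source reports. "The series", "measured", "known", "first", "only" and "open" are said of these compounds alone.

Compound 3 `c1csc(-c2cn3ccnc3c(-c3ccc4ncn(C5CCCCC5)c4c3)n2)c1` gives 46.4% in a functional assay on CCRF-CEM cells (Homo sapiens) for inhibition, read by sulforhodamine B assay, with a stated time of 48 h, tested at 10 uM (on this read-out lower numbers stand for less inhibition and higher numbers for more inhibition at the one concentration tested (going by the name of the read-out)), the highest of three numbers. Compound 1 `Fc1ccc(-c2cn3ccnc3c(-c3ccc4ncn(C5CCCCC5)c4c3)n2)cc1` gives 33.4% and compound 2 `COc1ccccc1-c1cn2ccnc2c(-c2ccc3ncn(C4CCCCC4)c3c2)n1` gives 17.4%; the steps of a number 13 percentage points higher from compound 1 to compound 3 (beyond the scatter) and a number 29 percentage points higher from compound 2 to compound 3 (beyond the scatter) both lie beyond the scatter. Compound 4 `FC(F)(F)c1cccc(-c2cn3ccnc3c(-c3ccc4ncn(C5CCCCC5)c4c3)n2)c1` differs from compound 3 by 3-(trifluoromethyl)phenyl in place of thiophen-2-yl on an aromatic carbon. The two measured steps bear on this: each time thiophen-2-yl stood in place of a six-membered carbon-only ring, the number rose, by a number 13 percentage points higher from compound 1 to compound 3 (beyond the scatter) and by a number 29 percentage points higher from compound 2 to compound 3 (beyond the scatter). Going the other way, a fall of similar size is therefore expected here, as a number 16.4 percentage points lower from compound 3 to compound 4 (beyond the scatter). Compound 4 is estimated to give 30%, in a range from 12% to 48%.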

Compound 4, a percentage reported as inhibition, at one concentration (the size of the read-out at that concentration, not a potency): 27.3%
Compound 4: the middle estimate sits 2.7 percentage points above what was measured; low and high end bracket the measured number.
By their numbers in this assay, from the lowest: compounds 2, 4 and 1 (each within the scatter of the next, the first and the last beyond it); then compound 3.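

Thiophen-2-yl now stands apart from a third six-membered carbon-only ring at this position, with a number 19.1 percentage points lower from compound 3 to compound 4 (beyond the scatter). The trifluoromethyl-bearing ring does not separate from either of the other two such rings, with a number 9.9 percentage points higher from compound 2 to compound 4 (within the scatter) and a number 6.1 percentage points lower from compound 1 to compound 4 (within the scatter). No measurement shown explains why the thiophene-bearing compound gives the higher number.

Still open, going by these compounds, is how a furan-2-yl or pyridin-3-yl ring, or a morpholine, would behave at this position. It is therefore unclear whether the higher number is particular to thiophen-2-yl or shared with other five-membered rings.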